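Amide aryl variation in the series

This account rests on a few compounds, and the source may have more. Where it says the series, first, only, none or still open, it means among the compounds named here.

The series shares one core and varies only the aryl on the amide-type nitrogen. Compound 1 `COc1ccc2c(=O)c(/C=C/C(=O)Nc3ccc(C)cc3)coc2c1` gives in a functional assay on Huh-7 cells (Homo sapiens) for inhibition, read by MTT assay, with a stated time of 48 h (on this read-out higher numbers stand for weaker inhibition and lower numbers for stronger inhibition), only a limit, > 100000 nM. Compound 2 `COc1ccc2c(=O)c(/C=C/C(=O)Nc3ccccc3OC)coc2c1` gives 32300 nM, and compound 3 `COc1cccc(NC(=O)/C=C/c2coc3cc(OC)ccc3c2=O)c1` gives 11100 nM, the lowest number among the three. Moving to 2-methoxyphenyl brought an at least 3.0-fold lower number from compound 1 to compound 2 (0.49 log units; beyond the scatter), moving to 3-methoxyphenyl brought an at least 9.0-fold lower number from compound 1 to compound 3 (0.95 log units; beyond the scatter), and between the two methoxy isomers there was a 2.9-fold lower number from compound 2 to compound 3 (0.46 log units; beyond the scatter). Compound 4 `COc1ccc2c(=O)c(/C=C/C(=O)Nc3ccccc3C)coc2c1` carries 2-methylphenyl in place of 3-methoxyphenyl on an amide-type nitrogen. This removes the 3-methoxyphenyl that gave a 2.9-fold lower number from compound 2 to compound 3 (0.46 log units; beyond the scatter) and returns to a methyl as in compound 1, so a higher number is expected, estimated at a 3.2-fold higher number from compound 3 to compound 4 (0.50 log units; beyond the scatter). Compound 4 is expected to give 35000 nM, within 12000 nM to 100000 nM.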

Compound 4, half-maximal inhibitory concentration: 26900 nM
Compound 4: the middle estimate sits 1.3-fold (0.11 log units) above what was measured; the measured number falls inside the stated range.
By their numbers in this assay, from the lowest: compound 3; then compounds 4 and 2 (each within the scatter of the next). At a limit, above all of these: compound 1.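

2-Methylphenyl and 2-methoxyphenyl on the amide-type nitrogen do not separate, with a 1.2-fold lower number from compound 2 to compound 4 (0.08 log units; within the scatter). The 3-methoxyphenyl of compound 3 keeps its advantage over 2-methylphenyl, with a 2.4-fold higher number from compound 3 to compound 4 (0.38 log units; beyond the scatter). Changing 4-methylphenyl to 2-methylphenyl gives an at least 3.7-fold lower number from compound 1 to compound 4 (0.57 log units; beyond the scatter), and this step is only a bound: the limit of > 100000 nM in this assay, at which 1 of the 4 values shown sits.

On these data alone, what 3-methylphenyl or 4-methoxyphenyl would give remains open, so the identity of the group cannot yet be separated from its placement. Also open, as far as these compounds go, is how an aryl carrying an amine or a carboxylic acid would behave in this assay.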